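This account rests on a few compounds, and the source may have more. Where it says the series, first, only, none or still open, it means among the compounds named here.

Working notes on the series. Compound 1 `Cc1cc(S(=O)(=O)/N=C(\N)n2nccc2-c2ccccc2)c(SCc2cccc(Cl)c2)cc1Cl` and compound 2 `Cc1cc(-c2ccccc2)n(/C(N)=N/S(=O)(=O)c2cc(C)c(Cl)cc2SCc2ccc(C(F)(F)F)cc2)n1` share a core in which a benzenesulfonyl group, carrying methyl, chlorine and a benzylthio arm, is linked through an amidine to a pyrazole bearing phenyl. In an ADME assay on HaCaT cells (Homo sapiens) for cytotoxicity, read by MTT assay, with a stated time of 72 h (on this read-out higher numbers stand for weaker inhibition and lower numbers for stronger inhibition), compound 1 gives 10000 nM, and compound 2 gives 18000 nM. Compound 2 carries the higher of the two numbers, but the two values sit within the scatter of each other, so no order between them can be read.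

The next step is compound 3 `Cc1cc(S(=O)(=O)/N=C(\N)n2nccc2-c2ccccc2)c(SCc2ccc(C(F)(F)F)cc2)cc1Cl`, which differs from compound 2 only by hydrogen in place of methyl on an aromatic carbon. Going by these compounds, nothing in the two measured compounds bears on this position, so the effect is unknown. Given how close compound 1 and compound 2 stand, a change no larger than the scatter is expected, with a 1.2-fold lower number from compound 2 to compound 3 (0.08 log units; within the scatter) as the anticipated step. Compound 3 is therefore estimated at 15000 nM, in the range 7000 nM to 35000 nM.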

Compound 3, half-maximal inhibitory concentration: 19000 nM
Compound 3: middle estimate off by 1.3-fold (0.10 log units), on the low side; the measured number falls inside the stated range.
By their numbers in this assay, from the lowest: compounds 1, 2 and 3 (each within the scatter of the next).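

In this assay the change from 3-methyl-5-phenyl-1H-pyrazol-1-yl to 5-phenyl-1H-pyrazol-1-yl gives a 1.1-fold higher number from compound 2 to compound 3 (0.02 log units; within the scatter) and so shows no readable effect of losing this methyl from the aromatic carbon. Within the data shown here, the first one-place comparison on the benzylthio arm, 4-(trifluoromethyl)phenyl in place of 3-chlorophenyl on a saturated chain carbon bound to a sulfur, gives a 1.9-fold higher number from compound 1 to compound 3 (0.28 log units; within the scatter) and likewise separates the two compounds by no readable margin. Nothing available explains either result.

Going by these compounds, whether an amine or a carboxylic acid on this aromatic carbon, or a longer chain in place of the methyl, would move the number beyond the scatter stays open. On these data alone, it is equally open whether a hydroxyl or a methoxy group on the phenyl of the benzylthio arm would do so.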